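This account rests on a few compounds, and the source may have more. Where it says the series, first, only, none or still open, it means among the compounds named here.

In an assay for inhibition of Fatty-acid amide hydrolase 1 (Rattus norvegicus) (on this read-out lower numbers stand for stronger inhibition and higher numbers for weaker inhibition), compound 3 `CS(=O)(=O)c1ccccc1CCCCCCC(=O)c1ncc(-c2ccccn2)o1` gives 37 nM, and compound 1 `O=C(CCCCCCc1cccnc1)c1ncc(-c2ccccn2)o1` gives 32 nM, a gap that lies within the scatter of repeated runs, so the two stand level. Compound 2 `O=C(O)c1ccc(CCCCCCC(=O)c2ncc(-c3ccccn3)o2)cc1` reaches only a limit of the assay, > 600 nM. Going by the values given here, the single measured step, an at least 18-fold higher number from compound 1 to compound 2 (1.27 log units; beyond the scatter), concerns a different part of the molecule and runs into the limit described by the limit of > 600 nM in this assay, at which 1 of the 3 values shown sits, so it says little about the change at hand. Compound 4 `CSc1ccccc1CCCCCCC(=O)c1ncc(-c2ccccn2)o1` differs from compound 3 by methylsulfanyl in place of methylsulfonyl on an aromatic carbon. Among the compounds with values here, no measured step tests this swap, and no shift beyond the scatter is expected. Compound 4 is estimated at 40 nM, within a range from 15 nM to 120 nM. The step of a 1.1-fold higher number from compound 3 to compound 4 (0.03 log units; within the scatter) is therefore expected to be small.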

Compound 4, inhibition constant: 3.3 nM
Estimate against measurement, compound 4: 12-fold (1.08 log units) above; the measured number lies below the stated range.
By their numbers in this assay, from the lowest: compound 4; then compounds 1 and 3 (each within the scatter of the next). At a limit, above all of these: compound 2.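

In this assay, the group on this aromatic carbon matters more than compounds 1 and 3, which stood level, could show: methylsulfanyl in place of methylsulfonyl gives an 11-fold lower number from compound 3 to compound 4 (1.05 log units; beyond the scatter). The 2-(methylsulfanyl)phenyl group also outdoes pyridin-3-yl, with a 9.7-fold lower number from compound 1 to compound 4 (0.99 log units; beyond the scatter). The step of an at least 180-fold lower number from compound 2 to compound 4 (2.25 log units; beyond the scatter) starts from a limit, not a number: the limit of > 600 nM in this assay, at which 1 of the 4 values shown sits.

On these data alone, whether sulfur itself is needed stays open, since methoxy or ethylsulfanyl on this carbon would test it. So would methylsulfinyl, which carries one oxygen on the sulfur.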